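The compounds below may be only part of what the source reports. "The series", "measured", "known", "first", "only" and "open" are said of these compounds alone.

Three ureas built on a shared core have been measured in an ADME assay on the whole organism with Oryza sativa as the target, tested at 10 uM; on this read-out lower numbers stand for a stronger effect and higher numbers for a weaker effect at the one concentration tested. Compound 2 `C[C@@H](NC(=O)Nc1ccccc1F)c1ccccc1` gives 77%. Compound 1 `C[C@@H](NC(=O)Nc1ccccc1C(F)(F)F)c1ccccc1` differs from compound 2 by trifluoromethyl in place of fluoro on an aromatic carbon. In this assay compound 1 gives 54%, a step of a number 23 percentage points lower from compound 2 to compound 1 (beyond the scatter). Compound 3 `C[C@@H](NC(=O)Nc1cc(F)ccc1F)c1ccccc1` differs from compound 2 by fluoro in place of hydrogen on an aromatic carbon. In this assay compound 3 gives 92%, a step of a number 15 percentage points higher from compound 2 to compound 3 (beyond the scatter), the highest of the three numbers.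

Compound 4 `C[C@@H](NC(=O)Nc1cc(C(F)(F)F)ccc1F)c1ccccc1` differs from compound 3 by trifluoromethyl in place of fluoro on an aromatic carbon. This is the same kind of change as that made from compound 2 to compound 1, yet the place is not the same: it sits meta to a large group and para to a fluoro group rather than ortho to a large group. Resting on the single earlier step of a number 23 percentage points lower from compound 2 to compound 1 (beyond the scatter), compound 4 is expected to show a step of a number 20 percentage points lower from compound 3 to compound 4 (beyond the scatter) in this assay. Compound 4 is therefore estimated at 72%, with a range from 52% to 92%.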

Compound 4, a percentage reported as activity, at one concentration (the size of the read-out at that concentration, not a potency): 60%
For compound 4 the middle estimate is 12 percentage points above the measured one; the range from low to high includes it.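

In this assay, trifluoromethyl in place of fluoro on the core of compound 3 brought a number 32 percentage points lower from compound 3 to compound 4 (beyond the scatter), while trifluoromethyl in place of hydrogen brought a number 17 percentage points lower from compound 2 to compound 4 (beyond the scatter). The step from compound 3 to compound 4 matches the earlier one in direction, and the two do not differ in size: the same change on two cores in this assay, a number 23 percentage points lower (beyond the scatter) from compound 2 to compound 1 and a number 32 percentage points lower (beyond the scatter) from compound 3 to compound 4, 9 percentage points apart, within the scatter of two such steps. The change therefore carried over between these two cores in this assay, even at different places on the ring, but two pairs do not show that it would hold on other cores or explain why it occurs.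

The compounds shown leave open whether a methoxy group, a nitrile or an amine in the same place would give a similar number. They also leave open how substituents on the other phenyl ring would act.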